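The source may hold more compounds than are shown below. What is called first, only, known or untested is meant among the compounds shown, and "the series" means these compounds.

Three analogues sharing one core have been measured in an assay on HEK293 cells for positive allosteric modulation of metabotropic glutamate receptor 2 (Rattus norvegicus), read by thallium flux, with a stated time of 2.5 min; on this read-out lower numbers stand for smaller maximal responses and higher numbers for larger maximal responses. Compound 1 `Cc1c(OCCCCOc2ccc(C(=O)O)cc2Cl)ccc(C(=O)CC2CCCC2)c1O` gives 82.2%; compound 2 `Cc1c(OCCCCOc2ccc(F)c(C(=O)O)c2)ccc(C(=O)CC2CCCC2)c1O` gives 81%; compound 3 `COc1ccc(C(=O)O)cc1OCCCCOc1ccc(C(=O)CC2CCCC2)c(O)c1C` gives 91.8%. Within the data shown here, compound 3 stands highest of the three, though its gap to compound 1 lies within the scatter; only the step of a number 10.8 percentage points higher from compound 2 to compound 3 (beyond the scatter) is beyond it.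

Compound 4 `Cc1c(OCCCCOc2ccc(C(=O)O)cc2F)ccc(C(=O)CC2CCCC2)c1O` differs from compound 3 in one place: 4-carboxy-2-fluorophenyl in place of 5-carboxy-2-methoxyphenyl on an oxygen on a saturated carbon. The two measured steps that bear on this, a number 9.6 percentage points higher from compound 1 to compound 3 (within the scatter) and a number 10.8 percentage points higher from compound 2 to compound 3 (beyond the scatter), both lead toward compound 3, so moving away from the 5-carboxy-2-methoxyphenyl group points downward. Compound 1 is the nearest analogue of compound 4, as its 4-carboxy-2-chlorophenyl group differs from 4-carboxy-2-fluorophenyl only in the halogen, and the step of a number 9.6 percentage points higher from compound 1 to compound 3 (within the scatter) was within the scatter. A step about that size, downward, is therefore expected: a number 8.8 percentage points lower from compound 3 to compound 4 (within the scatter). Compound 4 is estimated at 83% in this assay, with a likely range from 72% to 94%.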

Compound 4, largest response reached (reported as percent of maximum), in percent of the reference or control that the assay uses: 83.8%
For compound 4 the middle estimate is 0.8 percentage points below the measured one, and the stated range covers the measured number.
By their numbers in this assay, from the lowest: compounds 2, 1, 4 and 3 (each within the scatter of the next, the first and the last beyond it).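

Fluoro in place of chloro on an aromatic carbon gives a step of (a number 1.6 percentage points higher from compound 1 to compound 4 (within the scatter)), so in this assay this halogen exchange cannot be told apart from repeat measurement. The other two steps (a number 2.8 percentage points higher from compound 2 to compound 4 (within the scatter)) and (a number 8 percentage points lower from compound 3 to compound 4 (within the scatter)) also stay within the scatter, so compound 4 separates from none of the three earlier compounds, although compound 2 and compound 3 do separate from each other. No further data are available to tie these numbers to a cause.

Going from 5-carboxy-2-methoxyphenyl to 4-carboxy-2-fluorophenyl alters two features of the ring at once, and a 4-carboxy-2-methoxyphenyl or 5-carboxy-2-fluorophenyl group would be needed to pull them apart. As far as these compounds go, whether a tetrazole can stand in for the carboxylic acid also stays open.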